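The source may hold more compounds than are shown below. What is called first, only, known or untested is meant among the compounds shown, and "the series" means these compounds.

Three compounds share one core and carry different substituted phenyl groups on an aromatic nitrogen. In a functional assay on SGC-7901 cells (Homo sapiens) for inhibition, read by MTT assay, with a stated time of 24 h (a lower number here means a stronger inhibitor, a higher number a weaker inhibitor), compound 1 `CC1(C)[C@H]2CC[C@]1(C)N(Cc1cn(-c3ccccc3C#N)nn1)C(=O)C2` gives 260 nM, compound 2 `CC1(C)[C@H]2CC[C@]1(C)N(Cc1cn(-c3ccccc3F)nn1)C(=O)C2` gives 300 nM and compound 3 `CC1(C)[C@H]2CC[C@]1(C)N(Cc1cn(-c3ccc(Br)cc3)nn1)C(=O)C2` gives 450 nM. Compound 3 cannot be told apart from the other two: the gaps, a 1.5-fold higher number from compound 2 to compound 3 (0.18 log units; within the scatter) and a 1.7-fold higher number from compound 1 to compound 3 (0.24 log units; within the scatter), both lie within the usual scatter of repeated measurements.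

Going by the values given here, compound 4 `COc1cccc(-n2cc(CN3C(=O)C[C@@H]4CC[C@@]3(C)C4(C)C)nn2)c1` keeps the shared core and changes only that group, with 3-methoxyphenyl in place of 4-bromophenyl on an aromatic nitrogen. Among the compounds with values here, none of the measured compounds carries a 3-methoxyphenyl group, so the nearest evidence comes from the other changes to this phenyl group. Besides the two gaps already given, there is a 1.2-fold higher number from compound 1 to compound 2 (0.06 log units; within the scatter), and this one also stays within the scatter. Three small steps are thin evidence, and a new group could still break the pattern. Even so, they give no ground for expecting a real shift in this assay, in either direction. The estimated step is a 1.3-fold lower number from compound 3 to compound 4 (0.11 log units; within the scatter), which would remain within the scatter. Compound 4 is expected to give about 350 nM, with an estimated range of 150 nM to 800 nM.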

Compound 4, half-maximal inhibitory concentration: 590 nM
Compound 4: middle estimate off by 1.7-fold (0.23 log units), on the low side, and the stated range covers the measured number.
By their numbers in this assay, from the lowest: compounds 1, 2, 3 and 4 (each within the scatter of the next, the first and the last beyond it).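

In this assay, the change on this phenyl group now produces a gap that can be told apart from measurement noise, though only a modest one and only for one pair: a 2.3-fold higher number from compound 1 to compound 4 (0.36 log units; beyond the scatter), with 3-methoxyphenyl in place of 2-cyanophenyl. The other two comparisons stay within the scatter, with a 1.3-fold higher number from compound 3 to compound 4 (0.12 log units; within the scatter) and a 2.0-fold higher number from compound 2 to compound 4 (0.29 log units; within the scatter), so compound 4 cannot be separated from compound 2 or compound 3, and the series shows only a small spread across these four phenyl groups rather than a clear ranking. Nothing shown here explains why the one gap passes the scatter.

Each of the four groups differs from the others in both its substituent and that substituent's place on the phenyl ring, so the compounds shown cannot separate the two: a 3-bromophenyl or a 4-methoxyphenyl group would be needed to do that. Going by these compounds, it also remains open whether a group of a different kind on this ring, such as an amine or a carboxylic acid, would move the number much further than any of these four.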